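A few compounds are considered here, and "the series" means these few. Any claim that something is new, unique, unknown or untested is made for them only; others in the source may bear on it.

Measured compounds:
compound 1 `COc1ccc(-c2nc(C)c(C(=O)CSc3nc(-c4ccc(OC)cc4)c(C#N)c(=O)[nH]3)s2)cc1`, 97%
compound 2 `COc1ccc(-c2nc(SCC(=O)c3sc(-c4ccc(Cl)cc4)nc3C)[nH]c(=O)c2C#N)cc1`, 92.1%

In a functional assay on U-87MG ATCC cells for antiproliferative activity against U-87 MG (Homo sapiens), read by MTT assay, with a stated time of 48 h, tested at 5 uM (a lower number here means a stronger effect, a higher number a weaker effect of the compound at the concentration tested), compound 1 gives 97%, the highest of the two numbers; its nearest neighbour is compound 2, which in this assay gives 92.1%. Going by the values given here, the only step between them, a number 4.9 percentage points lower from compound 1 to compound 2 (within the scatter), lies within the scatter, so the two values cannot be placed in any order.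

Compound 3 `COc1ccc(-c2nc(C)c(C(=O)CSc3nc(-c4ccc(Cl)c(Cl)c4)c(C#N)c(=O)[nH]3)s2)cc1` has not yet been measured. It differs from compound 1 by 3,4-dichlorophenyl in place of 4-methoxyphenyl on an aromatic carbon. Among the compounds with values here, the one step that bears on this change is the exchange of a methoxy for a chloro on an aromatic carbon, a number 4.9 percentage points lower from compound 1 to compound 2 (within the scatter), which stayed within the scatter. On that basis a step no larger than the scatter is expected for a number 4 percentage points lower from compound 1 to compound 3 (within the scatter), with no direction beyond it. Compound 3 is therefore estimated at 93%, expected between 80% and 105% in this assay.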

Compound 3, a percentage reported as activity, at one concentration (the size of the read-out at that concentration, not a potency): 101%
Estimate against measurement, compound 3: 8 percentage points below; low and high end bracket the measured number.
By their numbers in this assay, from the lowest: compounds 2, 1 and 3 (each within the scatter of the next).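

In this assay, the exchange of 4-methoxyphenyl for 3,4-dichlorophenyl on the aromatic carbon ortho to a cyano group gives a number 4 percentage points higher from compound 1 to compound 3 (within the scatter). Going by these compounds alone, the earlier step lay at a different place in the molecule, so this is the first reading at this position, and it shows that a whole aryl group with two chlorines and no methoxy can stand here without a step beyond the scatter. Nothing available explains this result or links it to any property of either group.

The compounds shown leave open whether a group of another kind on this carbon, such as an amine, a carboxylic acid or a longer alkyl chain, would give a step beyond the scatter. They also leave open how an unsubstituted phenyl would read at this position.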